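Chloro for bromo on the aryl ketone of compound 3

A few compounds are considered here, and "the series" means these few. Any claim that something is new, unique, unknown or untested is made for them only; others in the source may bear on it.

Three compounds of this series carry the same core and have been run in a functional assay on MCF7 cells (Homo sapiens) for antiproliferative activity, read by sulforhodamine B assay, with a stated time of 72 h, tested at 10 uM; a lower number here means a stronger effect, a higher number a weaker effect of the compound at the concentration tested. Compound 1 `COC(=O)C1=C(N)Oc2c(OC)cc(Br)cc2C1CC(=O)c1ccc(Cl)cc1` gives 80.3%, compound 2 `COC(=O)C1=C(N)Oc2c(OC)cc(Br)cc2C1CC(=O)c1ccc(Br)cc1` gives 50.2% and compound 3 `COC(=O)C1=C(N)Oc2ccc(Br)cc2C1CC(=O)c1ccc(Br)cc1` gives 72.5%. On these numbers compound 3 stands second highest of three; its nearest neighbour is compound 1, within the scatter, and its furthest is compound 2, beyond the scatter, as the step of a number 22.3 percentage points higher from compound 2 to compound 3 (beyond the scatter) shows.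

Compound 4 `COC(=O)C1=C(N)Oc2ccc(Br)cc2C1CC(=O)c1ccc(Cl)cc1` differs from compound 3 in one place: chloro in place of bromo on an aromatic carbon. The measured step that bears on it is a number 30.1 percentage points lower from compound 1 to compound 2 (beyond the scatter), the same exchange run in the opposite direction on the methoxy-bearing core, a large step. Among the compounds with values here, no other pair shows this exchange. Reversing it would move the number upward, so the expected step of a number 19.5 percentage points higher from compound 3 to compound 4 (beyond the scatter) is upward and beyond the scatter; the read-out cannot rise far past full, which caps the estimate.

For compound 4 the value in this assay is therefore estimated at 92%, with a range from 72% to 110%.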

Compound 4, a percentage reported as activity, at one concentration (the size of the read-out at that concentration, not a potency): 67.6%
Compound 4: the middle estimate sits 24.4 percentage points above what was measured; measured number below the stated range.
By their numbers in this assay, from the lowest: compound 2; then compounds 4, 3 and 1 (each within the scatter of the next, the first and the last beyond it).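

In this assay, the exchange of 4-bromophenyl for 4-chlorophenyl on the core without methoxy gives a number 4.9 percentage points lower from compound 3 to compound 4 (within the scatter), so on this core the halogen on the aryl ketone makes no readable difference. The same exchange therefore does not carry over from one core to the other: the same change on two cores in this assay, a number 30.1 percentage points lower (beyond the scatter) from compound 1 to compound 2 and a number 4.9 percentage points higher (within the scatter) from compound 4 to compound 3, 35 percentage points apart, beyond the scatter of two such steps. The methoxy exchange also proves to depend on the halogen, since with the 4-chlorophenyl group it gives a number 12.7 percentage points lower from compound 1 to compound 4 (beyond the scatter), the opposite direction to the 4-bromophenyl pair: the same change on two cores in this assay, a number 22.3 percentage points higher (beyond the scatter) from compound 2 to compound 3 and a number 12.7 percentage points lower (beyond the scatter) from compound 1 to compound 4, 35 percentage points apart, beyond the scatter of two such steps.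

Within the data shown here, both gaps rest heavily on compound 2 at 50.2%, the only compound of the four whose steps to all the others lie beyond the scatter or whose combination of methoxy and 4-bromophenyl stands apart, and the data leave open whether this combination is a genuine interaction or specific to that one pairing. Also open, on these data alone, is how a fluoro or a trifluoromethyl group on the aryl ketone, or an ethoxy group in place of the methoxy, would behave on these two cores.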